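Trifluoromethyl Added to the Phenoxy Ring of Compound 1

The compounds below may be only part of what the source reports. "The series", "measured", "known", "first", "only" and "open" are said of these compounds alone.

Compound 1 `CCS(=O)(=O)Nc1ccc(Oc2ccccc2)c(-c2cn(C)c(=O)c3[nH]ccc23)c1`: < 45 mL/min/kg
Compound 2 `Cn1cc(-c2cc(S(N)(=O)=O)ccc2Oc2ccccc2)c2cc[nH]c2c1=O`: < 43.4 mL/min/kg

In an ADME assay on microsomes from liver (Homo sapiens) for metabolic stability, read by HPLC, using NADPH, with stated times of 5 min and 60 min, tested at 10 uM (on this read-out lower numbers stand for slow clearance and higher numbers for fast clearance), compound 1 gives < 45 mL/min/kg, which is a limit of the assay rather than a number. Compound 2 also sits at a limit, giving < 43.4 mL/min/kg in this assay. Among the measured compounds shown here, the only measured step, a step that the two limits leave unreadable from compound 1 to compound 2, therefore cannot be read, since the limit of < 43.4 mL/min/kg in this assay, at which 1 of the 2 values shown sits, and the limit of < 45 mL/min/kg in this assay, at which 1 of the 2 values shown sits, cap both values.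

Compound 3 `CCS(=O)(=O)Nc1ccc(Oc2ccc(C(F)(F)F)cc2)c(-c2cn(C)c(=O)c3[nH]ccc23)c1` differs from compound 1 by trifluoromethyl in place of hydrogen on an aromatic carbon. For the measured compounds named here, no measured step covers this change, and no step size can be drawn from two limits. Compound 3 is estimated at 30 mL/min/kg, between 10 mL/min/kg and 60 mL/min/kg. The step that the limit leaves unreadable from compound 1 to compound 3 is expected to stay within the scatter.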

Compound 3, clearance: 128 mL/min/kg
For compound 3 the middle estimate is 4.3-fold (0.63 log units) below the measured one; the measured number lies above the stated range.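

In this assay, among the compounds shown here, the phenoxy ring of compound 1 proves sensitive to substitution, which the earlier compounds did not show: trifluoromethyl in place of hydrogen, para to a large group, gives an at least 2.8-fold higher number from compound 1 to compound 3 (0.45 log units; beyond the scatter). This size is only a floor, since the value of compound 1 is a limit of the assay: the limit of < 45 mL/min/kg in this assay, at which 1 of the 3 values shown sits.

The compounds shown leave open whether a methyl group or a chlorine atom on the same aromatic carbon would give a similar rise. They also leave open whether the sulfamoyl series of compound 2 would respond to trifluoromethyl in the same way.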